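The compounds below may be only part of what the source reports. "The series", "measured", "known", "first", "only" and "open" are said of these compounds alone.

Three chlorides from one series have been run in a functional assay on KM12 cells (Homo sapiens) for cytotoxicity, read by sulforhodamine B assay, with a stated time of 48 h; a lower number here means a stronger inhibitor of growth, a higher number a weaker inhibitor of growth. Compound 1 `ClCc1ccc(Cn2cnc3nc(Cl)nc(Cl)c32)cc1` gives 670 nM, compound 2 `ClCc1ccccc1Cn1cnc2ncnc(Cl)c21` gives 11200 nM, and compound 3 `ClCc1ccccc1Cn1cnc2nc(Cl)nc(Cl)c21` gives 25700 nM. The difference between the core of compound 1 and the core of compound 3 is not broken down here. One change is measured within the pair: hydrogen in place of chloro on an aromatic carbon, which produced a 2.3-fold lower number from compound 3 to compound 2 (0.36 log units; beyond the scatter). Compound 4 `ClCc1ccc(Cn2cnc3ncnc(Cl)c32)cc1` carries the same change on compound 1, (hydrogen in place of chloro on an aromatic carbon), at a place described in the same words, so it is the same change. Given that step from compound 3 to compound 2, the step from compound 1 to compound 4 is expected to be a 2.2-fold lower number from compound 1 to compound 4 (0.35 log units; beyond the scatter), resting on the same change read in the same direction. Compound 4 is estimated at 300 nM in this assay, with a range from 120 nM to 800 nM.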

Compound 4, concentration for total growth inhibition: 3380 nM
Compound 4: the middle estimate sits 11-fold (1.05 log units) below what was measured; measured number above the stated range.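

Hydrogen in place of chloro on an aromatic carbon gives a 5.0-fold higher number from compound 1 to compound 4 (0.70 log units; beyond the scatter) in this assay. The same change therefore moves the number in opposite directions on the two cores, so in this series a step read on one core cannot be carried to the other: the same change on two cores in this assay, a 2.3-fold lower number (0.36 log units; beyond the scatter) from compound 3 to compound 2 and a 5.0-fold higher number (0.70 log units; beyond the scatter) from compound 1 to compound 4, 12-fold (1.06 log units) apart, beyond the scatter of two such steps

This rests on two pairs only, and it does not show which structural difference between the cores sets the gap, or how the change would read on any further core. Open, from the compounds shown here alone, is how an amine or a methoxy group on that same aromatic carbon would read on either core. Also open, going by these compounds, is what a hydroxymethyl group in place of the chloromethyl group would do.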